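The source may hold more compounds than are shown below. What is called first, only, known or untested is meant among the compounds shown, and "the series" means these compounds.

Compound 1 `O=c1cc(Cn2cc(CSC(=S)N3CCOCC3)nn2)c2ccc(O)cc2o1`: 40800 nM
Compound 2 `CC(C)(C)OC(=O)N1CCN(C(=S)SCc2cn(Cc3cc(=O)oc4cc(O)ccc34)nn2)CC1`: 48000 nM

Both compounds were tested in a functional assay on HeLa cells (Homo sapiens) for inhibition, read by MTT assay, with a stated time of 72 h; a lower number here means a stronger inhibitor, a higher number a weaker inhibitor. Compound 2 stands at the top of the two numbers, yet its gap to compound 1 lies within the scatter of repeated measurements, so the two cannot be told apart. The two compounds share a core and differ only in the ring appended through the thiocarbamate, and that change leaves the read-out unmoved.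

Compound 3 `O=c1cc(Cn2cc(CSC(=S)N3CCNCC3)nn2)c2ccc(O)cc2o1` is the next compound. It differs from compound 2 by hydrogen in place of tert-butoxycarbonyl on an amine nitrogen in a ring. Within the data shown here, no measured pair shows exactly this step. Because compound 1 with 40800 nM and compound 2 with 48000 nM sit so close despite different groups in this region, the expected step from compound 2 to compound 3, a 1.1-fold lower number from compound 2 to compound 3 (0.06 log units; within the scatter), is none beyond the scatter. Compound 3 is therefore expected to give 42000 nM, with a range from 15000 nM to 110000 nM.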

Compound 3, half-maximal inhibitory concentration: > 100000 nM
Compound 3 ended at the assay's limit; the forecaster's own chance of this, stated with the estimate: 10%; middle value at least 2.3-fold (0.37 log units) away from the limit.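

In this assay, compound 3 gives > 100000 nM, which is a limit of the assay and not a number. Hydrogen in place of tert-butoxycarbonyl on the ring amine nitrogen gives an at least 2.0-fold higher number from compound 2 to compound 3 (0.31 log units; beyond the scatter), and piperazin-1-yl in place of morpholin-4-yl on the thiocarbonyl carbon gives an at least 2.4-fold higher number from compound 1 to compound 3 (0.38 log units; beyond the scatter). Compound 1 and compound 2 could not be told apart, which made this region look indifferent to the group it carries, but compound 3 now shows that a ring nitrogen bearing only hydrogen does not fit that picture, and both steps rest on a single end point: the limit of > 100000 nM in this assay, at which 1 of the 3 values shown sits.

Going by these compounds, how far compound 3 lies beyond the limit remains unknown, so the full size of both steps cannot be read. Also open, on these data alone, is whether a methyl or acetyl group on that ring nitrogen would give a number close to that of compound 2.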